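This account rests on a few compounds, and the source may have more. Where it says the series, first, only, none or still open, it means among the compounds named here.

Working notes on the series. Two entries carry no result in a functional assay on CHO cells for agonist activity at Free fatty acid receptor 1 (Homo sapiens), read by FLIPR and calcium flux; a lower number here means that less compound is needed, a higher number that more compound is needed for the effect: compound 1 `Cc1cc(OCc2cccc(-c3c(C)cc(OCCCS(C)(=O)=O)cc3C)c2)ccc1N(CC(=O)O)C(=O)c1ccccc1` shows "not determined" (no result reported) and compound 2 `CC(=O)N(CC(=O)O)c1ccc(OCc2cccc(-c3c(C)cc(OCCCS(C)(=O)=O)cc3C)c2)cc1C` shows "not determined" (no result reported), so neither adds a number to the picture. The one figure in hand belongs to compound 3 `Cc1cc(O)cc(C)c1-c1cccc(COc2ccc(OCC(=O)O)c(F)c2)c1`, which in this assay gives 110 nM. With the other two entries blank, compound 3 is the only point of reference, and nothing about the size of a single change can be read off from measured pairs here.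

Compound 4 `COc1cc(C)c(-c2cccc(COc3ccc(OCC(=O)O)c(F)c3)c2)c(C)c1` differs from compound 3 in one place: methyl in place of hydrogen on an oxygen on an aromatic ring, hydroxy to methoxy on the 4-hydroxy-2,6-dimethylphenyl, which becomes 4-methoxy-2,6-dimethylphenyl. For the measured compounds named here, no measured pair shows this change, so the expectation rests on compound 3 alone. The step from compound 3 to compound 4 is expected to be small, a 1.6-fold higher number from compound 3 to compound 4 (0.21 log units; within the scatter), not clearly beyond the scatter, leaning toward needing somewhat more compound. Compound 4 is accordingly estimated at 180 nM in this assay, with a range from 60 nM to 600 nM.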

Compound 4, half-maximal effective concentration: 49.7 nM
Compound 4: middle estimate off by 3.6-fold (0.56 log units), on the high side, outside the stated range (below it).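

In this assay, methyl in place of hydrogen on an oxygen on an aromatic ring, hydroxy to methoxy, gives a 2.2-fold lower number from compound 3 to compound 4 (0.35 log units; beyond the scatter), the first measured size for a change at this position. In this pair the free hydroxy on the 4-hydroxy-2,6-dimethylphenyl is not needed for activity, and its replacement by methoxy lowers the number beyond the scatter. No available data bear on why the number falls with this change.

Going by these compounds, whether an ethoxy group, or an amine in place of the oxygen, would move the number in the same direction stays open. A single pair also leaves open whether the step from hydroxy to methoxy would keep its size and direction with the rest of the shared core changed.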